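This account rests on a few compounds, and the source may have more. Where it says the series, first, only, none or still open, it means among the compounds named here.

In an assay on HEK293 cells for inhibition of Leucine-rich repeat serine/threonine-protein kinase 2 variant G2019S (Homo sapiens), with a stated time of 48 h (a higher number here means a weaker inhibitor, a lower number a stronger inhibitor), the two measured compounds differ at the group carried on the aromatic nitrogen of the shared core. Compound 1 `Cc1nn(CC2(O)COC2)cc1Nc1nc(N)c2c(C#N)c(N3CCC[C@H]3C)n(C)c2n1` gives 250 nM in this assay. Compound 2 `Cc1c(Nc2nc(N)c3c(C#N)c(N4CCC[C@H]4C)n(C)c3n2)cnn1CC(C)(C)O` gives 120 nM in this assay, the lowest of the two numbers shown; its nearest neighbour is compound 1, whose number lies beyond the usual scatter above it, so compound 2 stands as the stronger of the two inhibitors here.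

Compound 3 `Cc1c(Nc2nc(N)c3c(C#N)c(N4CCC[C@H]4C)n(C)c3n2)cnn1[C@@H]1CCOC1` has not yet been measured in this assay. It differs from compound 2 in a single place: oxolan-3-yl in place of 2-hydroxy-2-methylpropyl on an aromatic nitrogen. Among the compounds with values here, no step between measured compounds follows this change, so the expectation rests only on the two values shown, and the replacement of one five-heavy-atom group by another of equal size gives little ground for expecting a move beyond the scatter in either direction. The step from compound 2 to compound 3 is therefore expected to be small, a 1.3-fold higher number from compound 2 to compound 3 (0.10 log units; within the scatter). Compound 3 is estimated to give 150 nM in this assay, within a range from 60 nM to 400 nM.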

Compound 3, half-maximal inhibitory concentration: 80 nM
Compound 3: middle estimate off by 1.9-fold (0.27 log units), on the high side; measured number inside the range.
By their numbers in this assay, from the lowest: compounds 3 and 2 (each within the scatter of the next); then compound 1.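

In this assay, within the data shown here, putting oxolan-3-yl in place of 2-hydroxy-2-methylpropyl on the aromatic nitrogen gives a 1.5-fold lower number from compound 2 to compound 3 (0.18 log units; within the scatter) and provides the first step that can be read at this position. The group that leaves has no ring and 1 hydrogen-bond donor, whereas the group that enters has a five-membered non-aromatic ring, 0 hydrogen-bond donors and 1 defined stereocentre, so for this pair the donor and the open chain are not needed to keep the number within the scatter. Nothing at hand explains why these two numbers lie so close together.

The compounds shown leave open whether the opposite stereocentre of the oxolan-3-yl group would give a similar number, and so whether the arrangement at that centre matters at this position. They also leave open how the number would respond to a group of another kind on this nitrogen, such as a piperidin-4-yl ring with its amine, a carboxylic acid on a longer chain, or a plain cyclopentyl ring with no oxygen.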